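Adding a Hydroxy Group to a Quinoline Hydrazone

A few compounds are considered here, and "the series" means these few. Any claim that something is new, unique, unknown or untested is made for them only; others in the source may bear on it.

Among the compounds with values here, compound 1 `O=C(N/N=C/c1ccc2ccccc2n1)c1ccccc1` is the weaker of the two measured members: in a functional assay on LNCaP cells (Homo sapiens) for cytotoxicity, read by MTT assay, with a stated time of 72 h (on this read-out lower numbers stand for stronger inhibition and higher numbers for weaker inhibition), compound 1 gives 20000 nM, while compound 2 `NC(=S)N/N=C/c1ccc2ccccc2n1` gives 16000 nM, a gap that lies within the scatter of this assay. Within the data shown here, no step between measured compounds is available to guide the next change. Compound 3 `O=C(N/N=C/c1ccc2ccccc2n1)c1ccccc1O` differs from compound 1 by hydroxy in place of hydrogen on an aromatic carbon. Among the measured compounds shown here, with no comparable step known, only a modest shift is expected from compound 1 to compound 3 in this assay, probably toward a lower number, that is a 2.0-fold lower number from compound 1 to compound 3 (0.30 log units; within the scatter). Compound 3 is therefore estimated at 10000 nM, within a range of 3000 nM to 30000 nM.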

Compound 3, half-maximal inhibitory concentration: 31000 nM
The estimate for compound 3 lay 3.1-fold (0.49 log units) below the measured number, and the stated range ends below it.
By their numbers in this assay, from the lowest: compounds 2, 1 and 3 (each within the scatter of the next).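

Putting hydroxy on an aromatic carbon ortho to a large group, the change from phenyl to 2-hydroxyphenyl, gives a 1.6-fold higher number from compound 1 to compound 3 (0.19 log units; within the scatter) in this assay, so this step cannot be told apart from ordinary assay scatter. At this position, then, hydroxy brings no gain that this read-out can detect. No measurement available here offers an explanation for the result. Still open, on these data alone, is whether an amine or a methoxy group on that same aromatic carbon would shift the number beyond the scatter.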